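The source may report more compounds than this note shows. Statements on the series, on what has been measured and on what is new or still open speak of the compounds shown alone.

In a functional assay on DU-145 cells (Homo sapiens) for inhibition, read by trypan blue exclusion, with a stated time of 96 h (on this read-out higher numbers stand for weaker inhibition of growth and lower numbers for stronger inhibition of growth), compound 3 `Nc1c(Br)cc(Br)cc1/C=C(/Sc1ccc(Br)cc1)C(=O)c1ccc(Br)cc1` gives > 100000 nM, which is a limit of the assay and not a number. Two relatives with the same shared core give real readings: compound 1 `O=C(/C(=C\c1c[nH]c2ccccc12)Sc1ccc(Br)cc1)c1ccc(Br)cc1` gives 1000 nM, and compound 2 `O=C(/C(=C\c1ccc(F)cc1F)Sc1ccc(Br)cc1)c1ccc(Br)cc1` gives 1000 nM. Their measured comparison shows no change at the digits printed from compound 1 to compound 2 (within the scatter), even though the 1H-indol-3-yl and 2,4-difluorophenyl groups look quite different.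

The next compound is compound 4 `O=C(/C(=C\c1ccc(F)cc1Cl)Sc1ccc(Br)cc1)c1ccc(Br)cc1`. It carries 2-chloro-4-fluorophenyl in place of 2-amino-3,5-dibromophenyl on a double-bonded chain carbon bound to a double-bonded chain carbon, and the change counts as 2-chloro-4-fluorophenyl in place of 2-amino-3,5-dibromophenyl on a double-bonded chain carbon bound to a double-bonded chain carbon.

Among the measured compounds shown here, two measured steps bear most directly on this change, since both bring in the group that compound 4 gives up. They are large: the data show an at least 100-fold higher number from compound 1 to compound 3 (2.00 log units; beyond the scatter), and also an at least 100-fold higher number from compound 2 to compound 3 (2.00 log units; beyond the scatter). For the measured compounds named here, removing that group is therefore expected to undo most of the loss, although no measured step shows this exact swap. The expected step in this assay is an at least 83-fold lower number from compound 3 to compound 4 (1.92 log units; beyond the scatter), a large move to a lower number, meaning stronger inhibition of growth. Compound 4 is estimated at 1200 nM, with an expected range from 300 nM to 6000 nM.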

Compound 4, concentration for 50% growth inhibition: 1000 nM
For compound 4 the middle estimate is 1.2-fold (0.08 log units) above the measured one; the measured number falls inside the stated range.
By their numbers in this assay, from the lowest: compounds 1, 2 and 4 (each within the scatter of the next). At a limit, above all of these: compound 3.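

In this assay, 2-chloro-4-fluorophenyl in place of 2-amino-3,5-dibromophenyl on a double-bonded chain carbon bound to a double-bonded chain carbon gives an at least 100-fold lower number from compound 3 to compound 4 (2.00 log units; beyond the scatter), so the loss seen with compound 3 follows the group that leaves and not the shared core. Chloro in place of fluoro on an aromatic carbon gives no change at the digits printed from compound 2 to compound 4 (within the scatter), and 2-chloro-4-fluorophenyl in place of 1H-indol-3-yl gives no change at the digits printed from compound 1 to compound 4 (within the scatter), so three different groups at this position now give readings within the scatter of one another. The reading of compound 3 is a limit and not a number: the limit of > 100000 nM in this assay, at which 1 of the 4 values shown sits.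

The compounds shown leave open whether the amino group, the two bromines or only their combination goes with the loss, as these parts appear together only in compound 3. A 2-aminophenyl or a 3,5-dibromophenyl group at this position would pull those parts apart, and a phenyl ring carrying a carboxylic acid would test whether the tolerance seen here reaches beyond the halogenated phenyl rings and the indole.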